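This account rests on a few compounds, and the source may have more. Where it says the series, first, only, none or still open, it means among the compounds named here.

Of the compounds shown here, three sharing one core have been measured in a functional assay on A549 cells (Homo sapiens) for cytotoxicity, read by MTT assay; a lower number here means a stronger inhibitor, a higher number a weaker inhibitor. Compound 1 `CCn1cc(-c2nc3ccc([N+](=O)[O-])cc3o2)c(=O)c2cc(F)c(N3CCNC(C)C3)c(F)c21` gives 900 nM, and compound 2 `CCn1cc(C(=O)Nc2ccccc2)c(=O)c2cc(F)c(N3CCNC(C)C3)c(F)c21`, with phenyl on an amide-type nitrogen, gives 39300 nM. Compound 3 `CCn1cc(C(=O)Nc2ccc(C)c([N+](=O)[O-])c2)c(=O)c2cc(F)c(N3CCNC(C)C3)c(F)c21` gives 3700 nM, the middle number of the three, higher than that of compound 1 and lower than that of compound 2.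

Compound 4 `CCn1cc(C(=O)NCc2ccc(OC)cc2)c(=O)c2cc(F)c(N3CCNC(C)C3)c(F)c21` has 4-methoxybenzyl in place of 4-methyl-3-nitrophenyl on an amide-type nitrogen of compound 3: 4-methoxybenzyl in place of 4-methyl-3-nitrophenyl on an amide-type nitrogen. Within the data shown here, the one measured step that bears on this change is an 11-fold lower number from compound 2 to compound 3 (1.03 log units; beyond the scatter), a large step made by putting 4-methyl-3-nitrophenyl in place of phenyl on that same nitrogen. Compound 4 no longer carries that group, so part of that step may be undone. Among the measured compounds shown here, no measured compound has 4-methoxybenzyl, which makes this a loose guide. A moderate rise in this assay is therefore expected, smaller than the measured step. The expected step is a 3.8-fold higher number from compound 3 to compound 4 (0.58 log units; beyond the scatter). Compound 4 is estimated at 14000 nM, with an expected range of 4000 nM to 45000 nM.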

Compound 4, half-maximal inhibitory concentration: 7000 nM
Beside the measured number, compound 4's estimate is 2.0-fold (0.30 log units) above it; low and high end bracket the measured number.
By their numbers in this assay, from the lowest: compound 1; then compounds 3 and 4 (each within the scatter of the next); then compound 2.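

In this assay the change from 4-methyl-3-nitrophenyl to 4-methoxybenzyl on the amide-type nitrogen gives a 1.9-fold higher number from compound 3 to compound 4 (0.28 log units; within the scatter), so these two groups cannot be told apart in this assay. Measured against plain phenyl on the same nitrogen, there is a 5.6-fold lower number from compound 2 to compound 4 (0.75 log units; beyond the scatter), which shows that a lower number than that of compound 2 does not require the 4-methyl-3-nitrophenyl group. No measurement is available to explain either step.

Compound 4 differs from compound 2 in both the added carbon link and the methoxy group, so the compounds shown do not reveal which of these accounts for the step. Plain benzyl and 4-methoxyphenyl on this nitrogen would separate the two, and a longer chain between the amide nitrogen and the ring also remains open.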